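This account rests on a few compounds, and the source may have more. Where it says the series, first, only, none or still open, it means among the compounds named here.

All values below come from a functional assay on A549 cells (Homo sapiens) for antiproliferative activity, read by MTT assay, with a stated time of 72 h; on this read-out higher numbers stand for weaker inhibition and lower numbers for stronger inhibition.

compound 1 `COc1cc(N(C)C)c(NC(=O)c2ccnc(Cl)c2)cc1Nc1nccc(-c2cn(C)c3ccccc23)n1`: 3430 nM
compound 2 `COc1cc(N(C)C)c(NC(=O)c2ccncc2OC)cc1Nc1nccc(-c2cn(C)c3ccccc23)n1`: 3030 nM
compound 3 `COc1cc(N(C)CCN(C)C)c(NC(=O)c2ccnc(Cl)c2)cc1Nc1nccc(-c2cn(CCCO)c3ccccc23)n1`: 2140 nM

Compound 2 differs from compound 1 by 3-methoxypyridin-4-yl in place of 2-chloropyridin-4-yl on a carbonyl carbon; the resulting step is a 1.1-fold lower number from compound 1 to compound 2 (0.05 log units; within the scatter). The difference between the core of compound 1 and the core of compound 3 is not broken down here.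

Compound 4 `COc1cc(N(C)CCN(C)C)c(NC(=O)c2ccncc2OC)cc1Nc1nccc(-c2cn(CCCO)c3ccccc23)n1` is not yet measured. It differs from compound 3 by 3-methoxypyridin-4-yl in place of 2-chloropyridin-4-yl on a carbonyl carbon, the same change as from compound 1 to compound 2, at the same place. Among the compounds shown this change occurs only once more, so the expectation rests on that single earlier step. For compound 4 in this assay the expected step is a 1.1-fold lower number from compound 3 to compound 4 (0.05 log units; within the scatter), because the same change gave a 1.1-fold lower number from compound 1 to compound 2 (0.05 log units; within the scatter). Compound 4 is therefore estimated at 1900 nM, with an expected range from 900 nM to 4000 nM.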

Compound 4, half-maximal inhibitory concentration: 2390 nM
Estimate against measurement, compound 4: 1.3-fold (0.10 log units) below; the range from low to high includes it.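

In this assay, 3-methoxypyridin-4-yl in place of 2-chloropyridin-4-yl gives a 1.1-fold higher number from compound 3 to compound 4 (0.05 log units; within the scatter). Set against the earlier step, the change carries from one core to the other with no difference that can be resolved: the same change on two cores in this assay, a 1.1-fold lower number (0.05 log units; within the scatter) from compound 1 to compound 2 and a 1.1-fold higher number (0.05 log units; within the scatter) from compound 3 to compound 4, 1.3-fold (0.10 log units) apart, within the scatter of two such steps. This shows that the change leaves the number within the scatter on these two cores, but it does not show the same on any other core, and neither step gives a direction.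

Still open, going by these compounds, is whether another group on the carbonyl carbon, such as a phenyl or a pyridine carrying an amine, would move the number beyond the scatter. On these data alone, the separate contributions of the differences between the core of compound 1 and the core of compound 3 also remain open.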